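Swapping Chlorophenyl for Indolyl: What to Expect

A few compounds are considered here, and "the series" means these few. Any claim that something is new, unique, unknown or untested is made for them only; others in the source may bear on it.

compound 1 `COc1cc(-c2ccnc3cc(-c4ccc(Cl)cc4)nn23)cc(OC)c1OC` — 1490 nM
compound 2 `COc1cc(-c2ccnc3c(-c4ccc(C)cc4)cnn23)cc(OC)c1OC` — > 10000 nM
compound 3 `COc1ccc(-c2cc3nccc(-c4cc(OC)c(OC)c(OC)c4)n3n2)cc1[N+](=O)[O-]` — > 10000 nM

For the measured compounds named here, in a functional assay on HeLa cells (Homo sapiens) for inhibition, read by CCK-8 assay, with a stated time of 48 h (a lower number here means a stronger inhibitor, a higher number a weaker inhibitor), compound 1 gives 1490 nM, the only actual number among the three. For compound 2 the assay reports only a limit, > 10000 nM. For compound 3 the result is likewise a limit, > 10000 nM. Compound 1 therefore stands alone as the one quantified inhibitor, with the limit of > 10000 nM in this assay, at which 2 of the 3 values shown sit, marking where the other two sit.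

Compound 4 `COc1cc(-c2ccnc3cc(-c4c[nH]c5ccccc45)nn23)cc(OC)c1OC` keeps the core of compound 1 and alters one group: 1H-indol-3-yl in place of 4-chlorophenyl on an aromatic carbon. Going by the values given here, no measured pair shows such a change, so the expected step from compound 1 to compound 4 rests on the change alone. The author expects a 1.7-fold lower number from compound 1 to compound 4 (0.22 log units; within the scatter), a modest gain not far beyond the scatter. For compound 4 the estimate is 900 nM, within 200 nM to 5000 nM.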

Compound 4, half-maximal inhibitory concentration: 195 nM
Estimate against measurement, compound 4: 4.6-fold (0.66 log units) above, and the stated range ends above it.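

In this assay 1H-indol-3-yl in place of 4-chlorophenyl gives a 7.6-fold lower number from compound 1 to compound 4 (0.88 log units; beyond the scatter) and so shows that this aromatic carbon, two ring bonds from the ring nitrogen, can carry a fused two-ring group with a real gain. No measurement shown gives a reason for this gain.

Whether the indole's ring hydrogen matters stays open, since a 1-methylindol-3-yl group does not appear among these compounds. As far as these compounds go, it is equally open whether a simple pyrrolyl ring, or an amine on the phenyl ring, would keep the gain.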